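The compounds below may be only part of what the source reports. "The series", "measured", "known", "first", "only" and "open" are said of these compounds alone.

Values in a functional assay on HCT-116 cells (Homo sapiens) for antiproliferative activity, read by MTT assay, with a stated time of 24 h; on this read-out higher numbers stand for weaker inhibition and lower numbers for stronger inhibition:
- Compound 1 `COc1cccc(/C=C/C(=O)c2ccc(OC)c3c2OC(C)(C)C=C3)c1`: > 10000 nM, a limit and not a number
- Compound 2 `COc1ccc(C(=O)/C=C/c2ccc(Br)cc2)c2c1C=CC(C)(C)O2`: > 10000 nM, a limit and not a number
- Compound 3 `COc1ccc(C(=O)/C=C/c2cccc([N+](=O)[O-])c2)c2c1C=CC(C)(C)O2`: 8050 nM

Compound 3 is the only one of the three with a real number. The rest stop at the limit of > 10000 nM in this assay, at which 2 of the 3 values shown sit.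

Compound 4 `COc1ccc(C(=O)/C=C/c2ccsc2)c2c1C=CC(C)(C)O2` follows from compound 3 by thiophen-3-yl in place of 3-nitrophenyl on a double-bonded chain carbon bound to a double-bonded chain carbon.

For the measured compounds named here, two measured steps bear on this. The closer is an at least 1.2-fold lower number from compound 2 to compound 3 (0.09 log units; that floor lies within the scatter), at the same place. The other is an at least 1.2-fold lower number from compound 1 to compound 3 (0.09 log units; that floor lies within the scatter). Both are floors and give no firm size.

Compound 4 gives up the 3-nitrophenyl that an at least 1.2-fold lower number from compound 2 to compound 3 (0.09 log units; that floor lies within the scatter) brought in, so a small move towards a higher number is expected, and a result at the limit is quite possible. The estimated step in this assay is a 1.6-fold higher number from compound 3 to compound 4 (0.21 log units; within the scatter).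

For compound 4 the expected value is 13000 nM, with an estimated range of 6000 nM to 30000 nM.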

Compound 4, half-maximal inhibitory concentration: > 10000 nM
Compound 4: no number, only a limit; the forecaster's own chance of this, stated with the estimate: 60%; the middle value lies beyond the limit too.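

In this assay compound 4 gives > 10000 nM, a limit and not a number, so a five-membered thiophen-3-yl ring at this place does not yield a measurable value. For the compounds shown here, the only readable step is an at least 1.2-fold higher number from compound 3 to compound 4 (0.09 log units; that floor lies within the scatter), and it gives no firm size. The steps from compound 1 and from compound 2 cannot be read, and 3-nitrophenyl remains the only group here with a number: the limit of > 10000 nM in this assay, at which 3 of the 4 values shown sit.

Going by these compounds, the order among 3-methoxyphenyl, 4-bromophenyl and thiophen-3-yl stays open. So does the outcome of an amine or a carboxylic acid on the aromatic ring at this place.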